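Swapping a Pyrrole for a Bromofuran in a Growth Inhibitor

The compounds below may be only part of what the source reports. "The series", "measured", "known", "first", "only" and "open" are said of these compounds alone.

Compound 1 `N#C/C(=C\c1ccc([N+](=O)[O-])cc1)C(=O)c1c[nH]c2ccccc12` and compound 2 `COc1ccc(CNC(=O)/C(C#N)=C/c2ccc[nH]2)cc1` were both tested in a functional assay on BE(2)-C cells (Homo sapiens) for inhibition, read by MTT assay, with a stated time of 72 h; on this read-out higher numbers stand for weaker inhibition of growth and lower numbers for stronger inhibition of growth. Compound 1 gave 40000 nM, and compound 2 gave 47000 nM; the two numbers sit within the usual scatter of each other, so neither can be called stronger or weaker. Compound 3 `COc1ccc(CNC(=O)/C(C#N)=C/c2cc(Br)co2)cc1` has not yet been measured in this assay. It differs from compound 2 in one place: 4-bromofuran-2-yl in place of 1H-pyrrol-2-yl on a double-bonded chain carbon bound to a double-bonded chain carbon. For the measured compounds named here, no measured pair shows such a change, so no step beyond the scatter is expected in either direction. For compound 3 the estimate in this assay is 40000 nM, between 15000 nM and 100000 nM, which means an expected step of a 1.2-fold lower number from compound 2 to compound 3 (0.07 log units; within the scatter).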

Compound 3, concentration for 50% growth inhibition: 36000 nM
Compound 3: the middle estimate sits 1.1-fold (0.05 log units) above what was measured, and the stated range covers the measured number.
By their numbers in this assay, from the lowest: compounds 3, 1 and 2 (each within the scatter of the next).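

In this assay the swap of 1H-pyrrol-2-yl for 4-bromofuran-2-yl gives a 1.3-fold lower number from compound 2 to compound 3 (0.12 log units; within the scatter) and so shows no readable effect of this change at this place. Trading the ring's hydrogen-bond donor for a hydrogen-bond acceptor and a bromine therefore leaves the two numbers within the scatter of each other. Nothing measured here accounts for this result. As far as these compounds go, it remains open whether another group at this place, such as an aminophenyl ring or a carboxylic acid on the ring, would give a step beyond the scatter. Which parts of the shared core matter for growth inhibition also remains open.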